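Taking the acetyl group off compound 3

The compounds below may be only part of what the source reports. "The series", "measured", "known", "first", "only" and "open" are said of these compounds alone.

In a functional assay on HL-60 cells (Homo sapiens), read by calcium flux (a lower number here means that less compound is needed, a higher number that more compound is needed for the effect), compound 3 `COc1ccc(Nc2c(C(C)=O)c(C)nn(CC(=O)Nc3ccc(Br)cc3)c2=O)cc1` gives > 50000 nM, which is a limit and not a number. Compound 1 `Cc1cc(Cc2cccc(Cl)c2)c(=O)n(CC(=O)Nc2ccc(Br)cc2)n1` gives > 50000 nM, again a limit. Compound 2 `Cc1cc(Cc2ccoc2)c(=O)n(CC(=O)Nc2ccc(Br)cc2)n1` gives > 50000 nM, likewise a limit. The whole set therefore stands at the limit of > 50000 nM in this assay, at which 3 of the 3 values shown sit, and compound 3 has no measured neighbour that would place it more exactly.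

The next compound, compound 4 `COc1ccc(Nc2cc(C)nn(CC(=O)Nc3ccc(Br)cc3)c2=O)cc1`, carries hydrogen in place of acetyl on an aromatic carbon, ortho to a (4-methoxyphenyl)amino group and ortho to a methyl group: hydrogen in place of acetyl on an aromatic carbon.

Among the measured compounds shown here, only one measured step exists, a step that the two limits leave unreadable from compound 1 to compound 2, and it concerns a different change. For the measured compounds named here, it has no readable size, and no measured step touches the acetyl group, so no size can be carried over. The most likely outcome in this assay is that compound 4 again reports only a limit, and any number that does appear could only lie on the side of less compound needed. The estimate amounts to an expected at least 1.4-fold lower number from compound 3 to compound 4 (0.15 log units; that floor lies within the scatter), and it is a weakly grounded one. For compound 4 the expected value is 35000 nM, with an estimated range from 8000 nM to 50000 nM.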

Compound 4, half-maximal effective concentration: > 50000 nM
Compound 4 gave a limit, no number (the forecaster's own chance of this, stated with the estimate: 70%); middle value at least 1.4-fold (0.15 log units) from the limit.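

In this assay compound 4 gives > 50000 nM, a limit and not a number, so its steps from compound 1, compound 2 and compound 3 join limit to limit and cannot be read. The compounds shown leave open what size, if any, the loss of acetyl has, and which change would give a measurable value in this assay.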